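Methyl on the indole core: expected effect on MCF7 growth inhibition

The compounds below may be only part of what the source reports. "The series", "measured", "known", "first", "only" and "open" are said of these compounds alone.

Measured compounds:
Compound 1, `COc1cc(/C(Cl)=C/C=C(\C#N)C(=O)c2c[nH]c3ccccc23)cc(OC)c1OC`, 94300 nM.
Compound 2, `N#C/C(=C\C=C(/Cl)c1ccc(Br)cc1)C(=O)c1c[nH]c2ccccc12`, 81500 nM.
Compound 3, `COc1cc(/C(Cl)=C/C=C(\C#N)C(=O)c2c(C)[nH]c3ccccc23)cc(OC)c1OC`, 83700 nM.

All three were tested in a functional assay on MCF7 cells (Homo sapiens) for cytotoxicity, read by sulforhodamine B assay, with a stated time of 48 h; on this read-out lower numbers stand for stronger inhibition of growth and higher numbers for weaker inhibition of growth. Compound 1 and compound 2 differ in the group attached to the chlorine-bearing carbon of the chain, and the difference between the two cores is not broken down here; their values, with compound 1 at 94300 nM and compound 2 at 81500 nM, lie within the usual scatter of each other, so no order between them can be stated.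

Compound 3 is compound 1 with the change (methyl in place of hydrogen on an aromatic carbon). This gave a 1.1-fold lower number from compound 1 to compound 3 (0.05 log units; within the scatter), a step that cannot be separated from repeat-measurement noise.

Compound 4, `Cc1[nH]c2ccccc2c1C(=O)/C(C#N)=C/C=C(\Cl)c1ccc(Br)cc1`, has not yet been measured. It stands to compound 2 as compound 3 stands to compound 1, carrying the change (methyl in place of hydrogen on an aromatic carbon); the place is described in the same words in both cases, so this is the same change made on a different core. Because a 1.1-fold lower number from compound 1 to compound 3 (0.05 log units; within the scatter) left the number essentially where it was, the expectation for compound 4 is a step of about a 1.1-fold lower number from compound 2 to compound 4 (0.04 log units; within the scatter) in this assay, again within scatter. Among the measured compounds shown here, with only one earlier example of the change, and that on a different core, the range around the expected number is kept wide. The estimated concentration for total growth inhibition of compound 4 in this assay is 75000 nM, expected between 35000 nM and 160000 nM.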

Compound 4, concentration for total growth inhibition: 73800 nM
Beside the measured number, compound 4's estimate is 1.0-fold (0.01 log units) above it, within the range that was stated.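

The methyl in place of hydrogen on an aromatic carbon, next to the ring nitrogen and next to the ring atom that bears a large group, gave a 1.1-fold lower number from compound 2 to compound 4 (0.04 log units; within the scatter) in this assay, so on this core too the number stayed where it was within repeat-measurement noise. Set beside the earlier step, the change reads the same on the two cores: the same change on two cores in this assay, a 1.1-fold lower number (0.05 log units; within the scatter) from compound 1 to compound 3 and a 1.1-fold lower number (0.04 log units; within the scatter) from compound 2 to compound 4, 1.0-fold (0.01 log units) apart, within the scatter of two such steps

This shows that, on these two cores and in this one read-out, the absence of a measurable step carried over from one core to the other, but it does not show that the methyl has any effect of its own, since neither step can be told from noise, and two cores cannot establish a rule for the wider series.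

Only hydrogen and methyl appear at this place in the compounds shown, so it remains open whether a longer chain such as ethyl, an amine or a carboxylic acid there would move the number beyond the scatter. Also open, from the compounds shown here alone, is whether the same methyl change would stay as silent on a core carrying another group in place of the chlorine on the chain, such as fluorine or a methoxy group.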